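Swapping the aryl group on the amine of compound 1

This account rests on a few compounds, and the source may have more. Where it says the series, first, only, none or still open, it means among the compounds named here.

Going by the values given here, in a functional assay on HT-29 cells (Homo sapiens) for cytotoxicity, read by sulforhodamine B assay (on this read-out higher numbers stand for weaker inhibition and lower numbers for stronger inhibition), compound 1 (`C=C1[C@@H](OC(C)=O)C[C@@H]2[C@](C)(CO[Si](C)(C)C(C)(C)C)[C@H](OC(C)=O)CC[C@@]2(C)[C@@H]1C[C@@H](Nc1ccc(F)cc1)C1=CCOC1=O`) gives 4940 nM, the lowest of the three numbers so far and beyond the scatter of the other two. Compound 2 (`C=C1[C@@H](OC(C)=O)C[C@@H]2[C@](C)(COC=O)[C@H](OC(C)=O)CC[C@@]2(C)[C@@H]1C[C@@H](Nc1ccc(F)cc1)C1=CCOC1=O`) gives 20500 nM, and compound 3 (`C=C1[C@@H](OC(C)=O)C[C@@H]2[C@](C)(COC=O)[C@H](OC(C)=O)CC[C@@]2(C)[C@@H]1C[C@@H](Nc1ccccc1)C1=CCOC1=O`) gives 28800 nM. Compound 4 (`C=C1[C@@H](OC(C)=O)C[C@@H]2[C@](C)(CO[Si](C)(C)C(C)(C)C)[C@H](OC(C)=O)CC[C@@]2(C)[C@@H]1C[C@@H](Nc1cccc(OC)c1)C1=CCOC1=O`) is not yet measured. It differs by 3-methoxyphenyl in place of 4-fluorophenyl on an amine nitrogen. Among the compounds with values here, the only measured change on that aryl group is a 1.4-fold higher number from compound 2 to compound 3 (0.15 log units; within the scatter), and it exchanges just fluoro for hydrogen. The other measured step, a 4.1-fold higher number from compound 1 to compound 2 (0.62 log units; beyond the scatter), concerns a group that compound 4 keeps unchanged. No shift beyond the scatter is expected, and the estimate is a 1.1-fold higher number from compound 1 to compound 4 (0.05 log units; within the scatter). Compound 4 is estimated at 5500 nM, with an expected range of 2500 nM to 12000 nM.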

Compound 4, half-maximal inhibitory concentration: > 50000 nM
Compound 4: a limit, no number (the forecaster's own chance of this, stated with the estimate: 3%); middle value at least 9.0-fold (0.95 log units) away from the limit.
By their numbers in this assay, from the lowest: compound 1; then compounds 2 and 3 (each within the scatter of the next). At a limit, above all of these: compound 4.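

Compound 4 gives > 50000 nM in this assay, and this is a limit of the assay, not a number. Going by these compounds alone, replacing 4-fluorophenyl with 3-methoxyphenyl on the amine nitrogen gives an at least 10-fold higher number from compound 1 to compound 4 (1.00 log units; beyond the scatter), whereas the only earlier change on this aryl group, a 1.4-fold higher number from compound 2 to compound 3 (0.15 log units; within the scatter), stayed within the scatter. The aryl group at this position can therefore shift the read-out well beyond the scatter, though the size of the step stays open-ended: the limit of > 50000 nM in this assay, at which 1 of the 4 values shown sits.

The compounds shown do not separate the loss of fluoro from the gain of methoxy. Going by these compounds, whether a hydroxy group or an amine in place of methoxy on the phenyl ring behaves the same way remains open.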